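Shortening the Chain in the Unsubstituted Carbamate

A few compounds are considered here, and "the series" means these few. Any claim that something is new, unique, unknown or untested is made for them only; others in the source may bear on it.

Compound 3 `O=C(OCCc1ccccc1)N(c1ccccc1)C1CN2CCC1CC2` carries a phenethyl group on the carbamate oxygen and no substituent on its outer ring. In an assay on CHO cells for displacement of a labelled ligand from muscarinic acetylcholine receptor M5 (Homo sapiens), read by scintillation counting, with a stated time of 2 h (a lower number here means a stronger inhibitor, a higher number a weaker inhibitor), compound 3 gives 260 nM, the highest number among the three measured compounds. Its two measured neighbours are the dichlorinated pair: compound 1 `O=C(OCCc1ccc(Cl)c(Cl)c1)N(c1ccccc1)C1CN2CCC1CC2` gives 80 nM and compound 2 `O=C(OCc1ccc(Cl)c(Cl)c1)N(c1ccccc1)C1CN2CCC1CC2` gives 60 nM. The step of a 3.3-fold higher number from compound 1 to compound 3 (0.51 log units; beyond the scatter) and the step of a 4.3-fold higher number from compound 2 to compound 3 (0.64 log units; beyond the scatter) both rise beyond the scatter, so the number goes up when the two chlorines are absent, at either chain length.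

Compound 4 `O=C(OCc1ccccc1)N(c1ccccc1)C1CN2CCC1CC2` has not yet been measured. Its change from compound 3 is phenyl in place of benzyl on a saturated chain carbon bound to an oxygen next to a carbonyl group. For the measured compounds named here, only one measured step is of the same kind, and it runs a 1.3-fold lower number from compound 1 to compound 2 (0.12 log units; within the scatter), a change that stays within the scatter. Because that single pair, a 1.3-fold lower number from compound 1 to compound 2 (0.12 log units; within the scatter), showed no real movement, the expectation for compound 4 in this assay is no step beyond the scatter, with at most a slight fall in the number. The expected step is a 1.3-fold lower number from compound 3 to compound 4 (0.11 log units; within the scatter). Compound 4 is therefore estimated to give about 200 nM, within a range from 80 nM to 500 nM.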

Compound 4, inhibition constant: 150 nM
Compound 4: middle estimate off by 1.3-fold (0.12 log units), on the high side, within the range that was stated.
By their numbers in this assay, from the lowest: compounds 2, 1, 4 and 3 (each within the scatter of the next, the first and the last beyond it).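

The change from phenethyl to benzyl can now be read on an outer ring without chlorines, and a 1.7-fold lower number from compound 3 to compound 4 (0.24 log units; within the scatter) again stays within the scatter, so in this assay neither pair shows chain length moving the number beyond the scatter. At the shorter chain, replacing 3,4-dichlorophenyl with phenyl gives a 2.5-fold higher number from compound 2 to compound 4 (0.40 log units; beyond the scatter) and this is a real rise, whereas changing the chlorines and the chain together gives a 1.9-fold higher number from compound 1 to compound 4 (0.27 log units; within the scatter) and stays within the scatter. Losing the two chlorines was first seen as a rise beyond the scatter at the longer chain, and it now appears at both chain lengths with a similar size: the same change on two cores in this assay, a 3.3-fold higher number (0.51 log units; beyond the scatter) from compound 1 to compound 3 and a 2.5-fold higher number (0.40 log units; beyond the scatter) from compound 2 to compound 4, 1.3-fold (0.11 log units) apart, within the scatter of two such steps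

The compounds leave open whether a chain longer than phenethyl would keep the number as level as these two lengths do. They also leave open which of the two chlorines matters, since a single chlorine on the outer ring, or an amine or a carboxylic acid in its place, does not appear among them.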